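Fluoro to nitro swap: expected outcome for compound 3

The source may report more compounds than this note shows. Statements on the series, on what has been measured and on what is new or still open speak of the compounds shown alone.

Measured so far in a functional assay on MCF7 cells (Homo sapiens) for inhibition, read by MTT assay, with a stated time of 48 h; a higher number here means a weaker inhibitor, a lower number a stronger inhibitor:
compound 1 `Fc1ccccc1CSc1nnc(-c2ccncc2)n1-c1ccccc1` — > 50000 nM
compound 2 `Fc1cccc(F)c1CSc1nnc(-c2ccncc2)n1-c1ccccc1` — > 50000 nM

Compound 1 reaches only the assay limit in this assay, > 50000 nM, not a measured number. Compound 2 likewise returns only a limit in this assay, > 50000 nM. Going by the values given here, the single measured step, a step that the two limits leave unreadable from compound 1 to compound 2, is therefore unreadable, with both ends resting at the limit of > 50000 nM in this assay, at which 2 of the 2 values shown sit. On the numbers shown compound 1 stands at that limit and nowhere else; no real potency is known for it.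

Compound 3 `O=[N+]([O-])c1ccccc1CSc1nnc(-c2ccncc2)n1-c1ccccc1` differs from compound 1 by nitro in place of fluoro on an aromatic carbon. Among the compounds with values here, no measured step touches this change: the one step concerns a second fluoro, and it gives no size because both of its values sit at the limit of > 50000 nM in this assay, at which 2 of the 2 values shown sit. There is thus no basis for expecting any step in this assay beyond the scatter, in either direction.

Compound 3 is expected to remain at the limit, with an estimated step that the limit leaves unreadable from compound 1 to compound 3 that carries no readable size. Compound 3 is estimated at 60000 nM, within 20000 nM to 200000 nM, and most likely the assay will again report only a limit.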

Compound 3, half-maximal inhibitory concentration: > 50000 nM
Compound 3 was reported as a limit; the forecaster's own chance of this, stated with the estimate: 80%; the middle value lies beyond the limit too.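

Going by these compounds alone, no step to compound 3 from compound 1 or compound 2 can be read in this assay, since all three results are limits and not numbers: the limit of > 50000 nM in this assay, at which 3 of the 3 values shown sit.

Where the real potency of compound 1, compound 2 and compound 3 lies, and whether nitro in place of fluoro alters it at all, stays open.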